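The source may report more compounds than this note shows. Statements on the series, on what has been measured and on what is new or still open speak of the compounds shown alone.

Of the compounds shown here, three of a shared core have been measured in a functional assay on liver (Rattus norvegicus, strain Sprague-Dawley) for inhibition, with a stated time of 1 h; a higher number here means a weaker inhibitor, a lower number a stronger inhibitor. Compound 3 `C=CCOc1cc(O)c2c(=O)c(O)c(-c3ccc4c(c3)OC(c3ccc(OCC=C)c(OC)c3)C(CO)O4)oc2c1` gives 22600 nM, the second highest of the three numbers. Compound 1 `C=CCCOc1cc(O)c2c(=O)c(O)c(-c3ccc4c(c3)OC(c3ccc(OCCC=C)c(OC)c3)C(CO)O4)oc2c1` gives 36200 nM, a number within the scatter of compound 3. Compound 2 `COc1cc(C2Oc3cc(-c4oc5cc(OCC(=O)N6CCCC6)cc(O)c5c(=O)c4O)ccc3OC2CO)ccc1OCC(=O)N1CCCC1` gives 900 nM, well below the other two, so among the three it inhibits most strongly. Compound 4 `C=CCOc1cc(O)c2c(=O)c(OCC=C)c(-c3ccc4c(c3)OC(c3ccc(OCC=C)c(OC)c3)C(CO)O4)oc2c1` is the next compound, differing from compound 3 in one place: allyl in place of hydrogen on an oxygen on an aromatic ring. Among the measured compounds shown here, no measured pair shows this change, so its effect is unknown. The expectation for compound 4 is a step of a 2.2-fold higher number from compound 3 to compound 4 (0.34 log units; beyond the scatter), likely towards a somewhat higher number, though possibly none beyond the scatter. Compound 4 is thus estimated at 50000 nM, within a range of 15000 nM to 150000 nM.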

Compound 4, half-maximal inhibitory concentration: 54800 nM
Compound 4: the middle estimate sits 1.1-fold (0.04 log units) below what was measured; the measured number falls inside the stated range.
By their numbers in this assay, from the lowest: compound 2; then compounds 3, 1 and 4 (each within the scatter of the next, the first and the last beyond it).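

In this assay, among the compounds shown here, turning hydroxy into allyloxy at this oxygen gives a 2.4-fold higher number from compound 3 to compound 4 (0.38 log units; beyond the scatter) and so weakens inhibition modestly, the first reading of any change at this position. Inhibition is still measurable once the hydrogen on this oxygen is gone, so a free hydroxy here is not required for it. Nothing available explains the size of this step. As far as these compounds go, whether a methyl, a longer chain or a chain ending in an amine on this oxygen would give a similar step stays open, as does whether allyl would have the same effect in compound 2.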